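The source may report more compounds than this note shows. Statements on the series, on what has been measured and on what is new or still open speak of the compounds shown alone.

For the measured compounds named here, compound 3 `Oc1cc(C(F)(F)F)ccc1-c1nc(-c2ccccc2O)n(-c2ccc(Cl)cc2Cl)n1` is one of three compounds so far measured in a functional assay on PC-12 cells (Rattus norvegicus) for cytotoxicity, read by MTT assay, with stated times of 2 h and 24 h, tested at 5 uM (a higher number here means a stronger effect of the compound at the concentration tested, a lower number a weaker effect), where compound 3 gives 86.7%. On the bare numbers it comes second of the three, but both gaps to the others lie within the scatter. Compound 2 `Oc1cc(C(F)(F)F)ccc1-c1nc(-c2ccccc2O)n(-c2ccccc2F)n1` gives 86.6%, and the step of a number 0.1 percentage points higher from compound 2 to compound 3 (within the scatter). Compound 1 `Oc1cc(C(F)(F)F)ccc1-c1nc(-c2ccccc2O)n(-c2ccc(C(F)(F)F)cc2)n1` gives 90.5%, and the step of a number 3.8 percentage points lower from compound 1 to compound 3 (within the scatter). The remaining step, a number 3.9 percentage points lower from compound 1 to compound 2 (within the scatter), likewise stays inside the scatter.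

Compound 4 `Cc1cc(C)cc(-n2nc(-c3ccc(C(F)(F)F)cc3O)nc2-c2ccccc2O)c1` has not yet been measured. It differs from compound 3 in a single place: 3,5-dimethylphenyl in place of 2,4-dichlorophenyl on an aromatic nitrogen. All three measured steps bear on this change, since each of them also exchanges the aryl group carried on that same aromatic nitrogen, and none of them shifted the read-out beyond the scatter, whether the group entering was 2-fluorophenyl, 2,4-dichlorophenyl or 4-(trifluoromethyl)phenyl. Putting 3,5-dimethylphenyl in that place is therefore expected to behave the same way, and the estimated step of no change at the digits printed from compound 3 to compound 4 (within the scatter) is expected to stay within the scatter. For compound 4 the estimate in this assay is 86.7%, with an expected range from 76% to 94%.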

Compound 4, a percentage reported as activity, at one concentration (the size of the read-out at that concentration, not a potency): 102%
The estimate for compound 4 lay 15.3 percentage points below the measured number; the whole stated range lies below it.
By their numbers in this assay, from the lowest: compounds 2, 3 and 1 (each within the scatter of the next); then compound 4.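

The aromatic nitrogen is not indifferent to the aryl group it carries in this assay: the step is a number 15.3 percentage points higher from compound 3 to compound 4 (beyond the scatter), and likewise a number 15.4 percentage points higher from compound 2 to compound 4 (beyond the scatter) and a number 11.5 percentage points higher from compound 1 to compound 4 (beyond the scatter), whereas the three halogen-bearing aryl groups could not be told apart. Compound 4 thus stands apart from all three earlier compounds, and its 3,5-dimethylphenyl group is the only one of the four aryl groups without a halogen, although it has the same 8 heavy atoms and the same single six-membered aromatic ring of carbon as the 2,4-dichlorophenyl group it replaces. Nothing in the data at hand explains why this exchange moves the read-out when the earlier ones did not.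

The compounds shown leave open whether the separation follows from the two methyl groups, from where they sit on the ring, or from the absence of halogen, which an unsubstituted phenyl, a single methyl group or a 3,5-dichlorophenyl group could help to separate. They also leave open how a methoxy group or an amine on this aryl ring would read in this assay.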